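Swapping 2-bromophenyl for 4-chlorophenyl on a carbonyl carbon

This account rests on a few compounds, and the source may have more. Where it says the series, first, only, none or still open, it means among the compounds named here.

compound 1 `COc1ccc(C(=O)c2cc(C)ccc2OCC(=O)NNC(=O)c2cc3ccccc3oc2=O)cc1` 41200 nM
compound 2 `Cc1ccc(OCC(=O)NNC(=O)c2cc3ccccc3oc2=O)c(C(=O)c2ccccc2Br)c1` 9400 nM
compound 3 `Cc1ccc(OCC(=O)NNC(=O)c2cc3ccccc3oc2=O)c(C(=O)c2ccccc2Cl)c1` 47600 nM

All three numbers come from a functional assay on Ehrlich cells (Mus musculus) for cytotoxicity, read by LDH release, with a stated time of 48 h (a lower number here means a stronger inhibitor, a higher number a weaker inhibitor), and compound 2 stands lowest among them, making it the strongest inhibitor of the set. Compound 4 `Cc1ccc(OCC(=O)NNC(=O)c2cc3ccccc3oc2=O)c(C(=O)c2ccc(Cl)cc2)c1` is still unmeasured. It carries 4-chlorophenyl in place of 2-bromophenyl on a carbonyl carbon.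

Within the data shown here, three measured steps bear on this change. Putting chloro in place of bromo on an aromatic carbon gave a 5.1-fold higher number from compound 2 to compound 3 (0.70 log units; beyond the scatter) as a modest step. Exchanging 4-methoxyphenyl for 2-bromophenyl gave a 4.4-fold lower number from compound 1 to compound 2 (0.64 log units; beyond the scatter) of similar size. Exchanging 4-methoxyphenyl for 2-chlorophenyl gave only a 1.2-fold higher number from compound 1 to compound 3 (0.06 log units; within the scatter) and so showed no real change. Among these compounds, only compound 2 stands apart. Among the measured compounds shown here, no measured compound carries 4-chlorophenyl, so this reading is uncertain. Since compound 3 also lost the bromo and gave a 5.1-fold higher number from compound 2 to compound 3 (0.70 log units; beyond the scatter) as its step, a modest rise is expected, toward a weaker inhibitor. The estimated step is a 3.5-fold higher number from compound 2 to compound 4 (0.55 log units; beyond the scatter) in this assay. For compound 4 the expected value is 33000 nM with an estimated range of 12000 nM to 80000 nM as its likely span.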

Compound 4, half-maximal inhibitory concentration: 58000 nM
Compound 4: the middle estimate sits 1.8-fold (0.24 log units) below what was measured; low and high end bracket the measured number.
By their numbers in this assay, from the lowest: compound 2; then compounds 1, 3 and 4 (each within the scatter of the next).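

In this assay, the step to the 4-chlorophenyl group gives a 6.2-fold higher number from compound 2 to compound 4 (0.79 log units; beyond the scatter), so a second chlorine-bearing group on this carbonyl carbon also falls short of the 2-bromophenyl group. Moving the chloro from the 2-chlorophenyl group to the 4-chlorophenyl group changes little, with a 1.2-fold higher number from compound 3 to compound 4 (0.09 log units; within the scatter), and the same holds for the exchange of methoxy for chloro, with a 1.4-fold higher number from compound 1 to compound 4 (0.15 log units; within the scatter). Compounds 1, 3 and 4 therefore read alike across three different groups at this position, which leaves compound 2, the only one carrying bromo, as the single exception and makes its lower number look less like a general effect of a halogen here. Nothing available explains why the 2-bromophenyl group stands apart.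

The compounds shown leave open whether the lower number follows bromo wherever it sits on the ring or only the 2-bromophenyl group. A 4-bromophenyl group would speak to that, and a 2-iodophenyl group or a plain phenyl on the same carbonyl carbon would show how far this single result extends.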